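Working notes: methoxy to hydroxy in compound 1

The compounds below may be only part of what the source reports. "The series", "measured", "known", "first", "only" and "open" are said of these compounds alone.

Values so far in a functional assay, read by spectrophotometry, with a stated time of 15 min (on this read-out lower numbers stand for stronger inhibition and higher numbers for weaker inhibition), are these.
- compound 1 `COc1ccc(-c2c3ccc4ccccc4c3nc3c2c(C)nc2c4ccccc4ccc32)cc1` gives 82.3 ug/mL
- compound 2 `Cc1nc2c3ccccc3ccc2c2nc3c(ccc4ccccc43)c(-c3cccc4ccccc34)c12` gives 64.3 ug/mL

Only these two compounds have been measured, and their values lie within the scatter of each other, so the position of compound 1 cannot be separated from that of compound 2. Compound 3 `Cc1nc2c3ccccc3ccc2c2nc3c(ccc4ccccc43)c(-c3ccc(O)cc3)c12` is still unmeasured. It differs from compound 1 by hydrogen in place of methyl on an oxygen on an aromatic ring, which is hydrogen in place of methyl on an oxygen on an aromatic ring, or 4-methoxyphenyl to 4-hydroxyphenyl.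

Going by the values given here, one measured step bears on this change, and only indirectly. Naphthalen-1-yl in place of 4-methoxyphenyl on an aromatic carbon gave a 1.3-fold lower number from compound 1 to compound 2 (0.11 log units; within the scatter), so exchanging the whole group left the read-out within the scatter. Among the compounds with values here, no measured step alters the group on the oxygen itself, and the data therefore favour no direction. A change within the scatter is expected in this assay, though this rests on thin evidence. The estimated step is a 1.1-fold lower number from compound 1 to compound 3 (0.04 log units; within the scatter) and the range is kept wide. Compound 3 is expected at 75 ug/mL, with an estimated range of 38 ug/mL to 140 ug/mL.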

Compound 3, half-maximal inhibitory concentration: 44.1 ug/mL
For compound 3 the middle estimate is 1.7-fold (0.23 log units) above the measured one; measured number inside the range.
By their numbers in this assay, from the lowest: compounds 3, 2 and 1 (each within the scatter of the next).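

In this assay the change of methyl to hydrogen on an oxygen on an aromatic ring now has a direct reading (a 1.9-fold lower number from compound 1 to compound 3 (0.27 log units; within the scatter)), so methoxy and hydroxy at this place cannot be told apart on these numbers. The exchange of the whole group reads the same way (a 1.5-fold lower number from compound 2 to compound 3 (0.16 log units; within the scatter)), which puts 4-methoxyphenyl, 4-hydroxyphenyl and naphthalen-1-yl within the scatter of one another and gives no order among the three compounds. No measurement available for these compounds accounts for the read-out at this position.

As far as these compounds go, it stays open whether a more distant replacement, such as an amine or a carboxylic acid in place of the hydroxy, or an ethyl or longer chain in place of the methyl on the oxygen, would carry the read-out beyond the scatter. The methyl on the shared core is also common to all three compounds, so the series says nothing about hydrogen or a larger alkyl chain in its place.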